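Lengthening the Vinyl Group of Compound 2

A few compounds are considered here, and "the series" means these few. Any claim that something is new, unique, unknown or untested is made for them only; others in the source may bear on it.

For the measured compounds named here, in a functional assay on HeLa cells (Homo sapiens) for inhibition, read by MTT assay, with a stated time of 72 h (on this read-out lower numbers stand for stronger inhibition and higher numbers for weaker inhibition), compound 2 (`C=CC(=O)Nc1cccc(Oc2nc(Nc3cccc(C#N)c3)nc3ccsc23)c1`) gives 6390 nM, the lower of the two numbers so far, while compound 1 (`C=CC(=O)Nc1cccc(Oc2nc(Nc3cccc(OC)c3)nc3ccsc23)c1`) gives 16400 nM. Compound 3 (`CC(C)/C=C/C(=O)Nc1cccc(Oc2nc(Nc3cccc(C#N)c3)nc3ccsc23)c1`) differs from compound 2 in one place, with 3-methylbut-1-en-1-yl in place of vinyl on a carbonyl carbon. Going by the values given here, the only measured step, a 2.6-fold lower number from compound 1 to compound 2 (0.41 log units; beyond the scatter), was modest and swapped methoxy for cyano elsewhere, so it is merely a loose guide to size. In this assay, a modest move towards a higher number is expected, a 1.9-fold higher number from compound 2 to compound 3 (0.27 log units; within the scatter). For compound 3 the estimated value is 12000 nM, within a range of 4000 nM to 40000 nM.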

Compound 3, half-maximal inhibitory concentration: 36500 nM
Compound 3: the middle estimate sits 3.0-fold (0.48 log units) below what was measured; measured number inside the range.
By their numbers in this assay, from the lowest: compound 2; then compound 1; then compound 3.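

In this assay, the group on the carbonyl carbon clearly matters: 3-methylbut-1-en-1-yl in place of vinyl gives a 5.7-fold higher number from compound 2 to compound 3 (0.76 log units; beyond the scatter), so inhibition weakens. The double bond outside the aromatic rings and the zero counts of hydrogen-bond donors and acceptors stay the same, while the group grows from 2 to 5 carbons. Nothing available explains this loss. As far as these compounds go, it remains open whether a straight butenyl chain would give a similar number, and whether a chain ending in a dimethylamino group would recover inhibition.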